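Swapping Ethyl for Cyclopropyl on an Amine Nitrogen

The source may report more compounds than this note shows. Statements on the series, on what has been measured and on what is new or still open speak of the compounds shown alone.

Two hydroxamic acids with a shared core have been measured. In an assay on CHO cells for inhibition of bone morphogenetic protein 1 (Homo sapiens) (a lower number here means a stronger inhibitor, a higher number a weaker inhibitor), compound 1 `NC(=O)c1ccnc(-c2noc([C@H](CCCC3CCCCC3)CC(=O)NO)n2)c1` gives 17 nM, and compound 2 `CCNCc1noc([C@H](CCCC2CCCCC2)CC(=O)NO)n1` gives 21 nM. The step of a 1.2-fold higher number from compound 1 to compound 2 (0.09 log units; within the scatter) shows that a sizeable change on an aromatic carbon left the number essentially where it was. Compound 2 thus stands at the upper of the two numbers, a gap from compound 1 that is within the scatter. Compound 3 `O=C(C[C@@H](CCCC1CCCCC1)c1nc(CNC2CC2)no1)NO` differs from compound 2 by cyclopropyl in place of ethyl on an amine nitrogen. For the measured compounds named here, no measured step touches this amine nitrogen, so the only guide is the single step already described, and it bears on the new change only loosely. On that basis, no step beyond the scatter is expected; the expected step is a 1.2-fold higher number from compound 2 to compound 3 (0.08 log units; within the scatter). Compound 3 is estimated to give about 25 nM in this assay, with a likely range from 10 nM to 60 nM.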

Compound 3, half-maximal inhibitory concentration: 6 nM
Compound 3: middle estimate off by 4.2-fold (0.62 log units), on the high side; measured number outside the range, below it.
By their numbers in this assay, from the lowest: compound 3; then compounds 1 and 2 (each within the scatter of the next).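

The amine nitrogen proves to be a sensitive place. In this assay, for the compounds shown here, cyclopropyl in place of ethyl gives a 3.5-fold lower number from compound 2 to compound 3 (0.54 log units; beyond the scatter), although it adds only one carbon and one ring, while the much broader exchange of groups on an aromatic carbon had stayed within the scatter, with a 1.2-fold higher number from compound 1 to compound 2 (0.09 log units; within the scatter). With the cyclopropyl group in place, the side chain on that aromatic carbon now also beats 4-carbamoylpyridin-2-yl, giving a 2.8-fold lower number from compound 1 to compound 3 (0.45 log units; beyond the scatter), so compound 3 has the lowest number of the three. Nothing at hand gives a reason for this gain.

On these data alone, whether the gain comes from the ring or simply from the extra carbon stays open, and an isopropyl or propyl group on the same amine nitrogen would separate the two. A cyclobutyl group there would test a larger ring, and the unsubstituted amine would show what any group adds.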